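A few compounds are considered here, and "the series" means these few. Any claim that something is new, unique, unknown or untested is made for them only; others in the source may bear on it.

In a functional assay on MDA-MB-231 cells (Homo sapiens) for antiproliferative activity, read by sulforhodamine B assay, with a stated time of 72 h; a higher number here means a weaker inhibitor, a lower number a stronger inhibitor:
Compound 1 `COc1cc2occ(-c3csc4ccccc34)c(=O)c2c(OC)c1OC`: 820 nM
Compound 2 `COc1cc2occ(-c3csc4ccccc34)c(=O)c2c(OC)c1O`: > 10000 nM

Compound 2 gives only a limit, > 10000 nM, and not a number. Compound 3 `CCOc1c(OC)cc2occ(-c3csc4ccccc34)c(=O)c2c1OC` caps its free hydroxy: ethyl in place of hydrogen on an oxygen on an aromatic ring. Among the compounds with values here, one measured step bears on this, an at least 12-fold higher number from compound 1 to compound 2 (1.08 log units; beyond the scatter), a large rise in the number when hydrogen took the place of methyl on that oxygen. Ethyl on the oxygen restores a capped form, though not the same group as in compound 1, so a large drop in the number is expected, and the estimated step is an at least 6.6-fold lower number from compound 2 to compound 3 (0.82 log units; beyond the scatter). For compound 3 the estimate is 1500 nM, with an expected range of 400 nM to 7000 nM.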

Compound 3, half-maximal inhibitory concentration: 5200 nM
Compound 3: the middle estimate sits 3.5-fold (0.54 log units) below what was measured, within the range that was stated.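

Swapping the methyl on this oxygen for ethyl gives a 6.3-fold higher number from compound 1 to compound 3 (0.80 log units; beyond the scatter), so at this position the identity of the capping group matters, not only whether the hydroxy is capped. Compound 2 gives only a limit, not a number: the limit of > 10000 nM in this assay, at which 1 of the 3 values shown sits. Capping the hydroxy therefore reads as an at least 1.9-fold lower number from compound 2 to compound 3 (0.28 log units; that floor lies within the scatter), which leaves the true size of any recovery unknown. From the compounds shown here alone, whether a longer chain such as propyl on this oxygen would raise the number further remains open. Going by these compounds, how a chain ending in an amine would behave there is also open.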